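Diethylamino in Place of Pyrrolidinyl on a Fused Core

The compounds below may be only part of what the source reports. "The series", "measured", "known", "first", "only" and "open" are said of these compounds alone.

Measured compounds:
compound 1 `Cc1cccc(C)c1Nc1nc2c(Nc3ccc(C(F)(F)F)cc3)ncnc2s1`: 23 nM
compound 2 `Cc1nc(Nc2ccc(C(F)(F)F)c(Cl)c2)c2nc(Nc3c(Cl)cccc3Cl)sc2n1`: 3 nM
compound 3 `FC(F)(F)c1ccc(Nc2nc(N3CCCC3)nc3sc(Nc4c(Cl)cccc4Cl)nc23)cc1`: 12 nM

In a functional assay on HEK293 cells for antagonist activity at transient receptor potential cation channel subfamily V member 1 (Homo sapiens), read by calcium flux (on this read-out lower numbers stand for stronger inhibition and higher numbers for weaker inhibition), compound 3 stands second highest of the three numbers. Compound 1 lies within the scatter of compound 3, so the two cannot be told apart on this read-out. Compound 2 lies beyond the scatter below compound 3.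

Compound 4 `CCN(CC)c1nc(Nc2ccc(C(F)(F)F)cc2)c2nc(Nc3c(Cl)cccc3Cl)sc2n1` has not been measured. It differs from compound 3 in one place: diethylamino in place of pyrrolidin-1-yl on an aromatic carbon. Going by the values given here, no step between measured compounds matches this change, so only the size of the group gives a hint. In this assay compound 4 is expected to give about 12 nM, between 5 nM and 30 nM. The estimated step of no change at the digits printed from compound 3 to compound 4 (within the scatter) is expected to stay within the scatter.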

Compound 4, half-maximal inhibitory concentration: 48 nM
Compound 4: the middle estimate sits 4.0-fold (0.60 log units) below what was measured; the whole stated range lies below it.
By their numbers in this assay, from the lowest: compound 2; then compounds 3 and 1 (each within the scatter of the next); then compound 4.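

In this assay, diethylamino in place of pyrrolidin-1-yl gives a 4.0-fold higher number from compound 3 to compound 4 (0.60 log units; beyond the scatter), a step beyond the scatter. The position, on an aromatic carbon between two ring nitrogen atoms, therefore tells these two groups apart, although the counts of heavy atoms, donors and acceptors stay the same and the ring is what differs. No measurement at hand accounts for the step. The compounds shown leave open how piperidine, morpholine or azetidine would read at this position. They also leave open whether dimethylamino would follow diethylamino.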